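The compounds below may be only part of what the source reports. "The series", "measured", "known", "first", "only" and "open" are said of these compounds alone.

In a functional assay on CHO cells for antagonist activity at transient receptor potential cation channel subfamily V member 1 (Rattus norvegicus), read by fluorescence, with a stated time of 1 h (on this read-out lower numbers stand for stronger inhibition and higher numbers for weaker inhibition), compound 3 `CC(C(=O)NCc1ccc(C(C)(C)C)cc1)c1ccc(NS(C)(=O)=O)c(Br)c1` gives 25 nM, the second highest of the three numbers measured. Its nearest neighbour is compound 2 `CC(C(=O)NCc1ccc(C(C)(C)C)cc1)c1ccc(NS(C)(=O)=O)c(Cl)c1`, which gives 29.5 nM, and the furthest is compound 1 `CC(C(=O)NCc1ccc(C(C)(C)C)cc1)c1ccc(NS(C)(=O)=O)cc1`, which gives 17.5 nM. The steps among these compounds are a 1.7-fold higher number from compound 1 to compound 2 (0.23 log units; within the scatter), a 1.4-fold higher number from compound 1 to compound 3 (0.15 log units; within the scatter) and a 1.2-fold lower number from compound 2 to compound 3 (0.07 log units; within the scatter), each within the scatter. Compound 4 `CC(C(=O)NCc1ccc(C(C)(C)C)cc1)c1ccc(NS(C)(=O)=O)c(I)c1` differs from compound 3 by iodo in place of bromo on an aromatic carbon. Among the measured compounds shown here, the steps that bear on this change, a 1.2-fold lower number from compound 2 to compound 3 (0.07 log units; within the scatter) and a 1.4-fold higher number from compound 1 to compound 3 (0.15 log units; within the scatter), were both within the scatter, so no step beyond the scatter is expected in this assay in either direction. Compound 4 is therefore estimated at 27 nM, with a range from 12 nM to 60 nM. This expectation amounts to a 1.1-fold higher number from compound 3 to compound 4 (0.03 log units; within the scatter).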

Compound 4, inhibition constant: 30 nM
For compound 4 the middle estimate is 1.1-fold (0.05 log units) below the measured one; low and high end bracket the measured number.
By their numbers in this assay, from the lowest: compounds 1, 3, 2 and 4 (each within the scatter of the next).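

In this assay iodo ortho to a methanesulfonamido group stays within the scatter of bromo (a 1.2-fold higher number from compound 3 to compound 4 (0.08 log units; within the scatter)), of chloro (a 1.0-fold higher number from compound 2 to compound 4 (0.01 log units; within the scatter)) and of hydrogen (a 1.7-fold higher number from compound 1 to compound 4 (0.23 log units; within the scatter)). Iodo thus joins chloro and bromo as a third halogen at this place, and none of the four compounds can be set apart from the others. Nothing available explains this result. Still open, from the compounds shown here alone, is whether an amine, a carboxylic acid or a longer chain at this place would give a step beyond the scatter.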